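Inverting one ring stereocentre in a cyclic amino acid

The source may hold more compounds than are shown below. What is called first, only, known or untested is meant among the compounds shown, and "the series" means these compounds.

Compound 1 `O=C(O)[C@@H]1NCC=C[C@@H]1O`: 1.3%
Compound 2 `O=C(O)[C@H]1NC[C@H](O)[C@@H](O)[C@@H]1O`: 0.2%
Compound 3 `O=C(O)[C@@H]1NC[C@@H](O)[C@@H](O)[C@H]1O`: 8.2%

Three cyclic amino acids have been measured in an assay for inhibition of alpha-N-acetylgalactosaminidase (Gallus gallus), tested at 1000 uM; on this read-out higher numbers stand for more inhibition at the one concentration tested (going by the name of the read-out) and lower numbers for less inhibition. Compound 1 gives 1.3% in this assay, compound 2 gives 0.2% and compound 3 gives 8.2%. Compound 1 stands second highest of the three, but its gaps to both neighbours fall within the scatter of repeated measurements, so the three values cannot be ordered with confidence.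

Compound 4 `O=C(O)[C@@H]1NCC=C[C@H]1O` has not yet been measured. It differs from compound 1 as follows: the two compounds have the same atoms and bonds and differ only in configuration as drawn: 1 of 2 stereo elements differ; a stereocentre at a saturated ring carbon is drawn S in compound 1 and R in compound 4

Within the data shown here, the only measured step that changes configuration alone is that from compound 2 to compound 3, a number 8 percentage points higher from compound 2 to compound 3 (within the scatter), supported by the fact that compounds 2 and 3 differ only in the configuration as drawn. That step did not move the number beyond the scatter, and all three values sit near the bottom of the scale. A change in configuration at one saturated ring carbon is therefore expected to give no step beyond the scatter: compound 4 is estimated at 3%, between 0% and 12%, a step of a number 1.7 percentage points higher from compound 1 to compound 4 (within the scatter).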

Compound 4, a percentage reported as inhibition, at one concentration (the size of the read-out at that concentration, not a potency): 3.2%
Beside the measured number, compound 4's estimate is 0.2 percentage points below it, within the range that was stated.
By their numbers in this assay, from the lowest: compounds 2, 1, 4 and 3 (each within the scatter of the next).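

In this assay, inverting this one saturated ring carbon gives a number 1.9 percentage points higher from compound 1 to compound 4 (within the scatter). Among these compounds, the earlier configuration step changed three stereo elements at once, so this pair is the first to test a single stereocentre on its own, and that single inversion also gives no step beyond the scatter. The reading of the pair is a clean one, as no other structural feature separates the two compounds: the fact that compounds 1 and 4 differ only in the configuration as drawn

On these data alone, with all four compounds near the bottom of the scale, it remains open whether this stereocentre would matter in a compound that inhibits more strongly at this concentration. Also open, as far as these compounds go, is whether a methyl ester in place of the carboxylic acid, or an acetyl group on the amine, would lift the number beyond the scatter.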